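The compounds below may be only part of what the source reports. "The series", "measured", "known", "first", "only" and "open" are said of these compounds alone.

Measured in an ADME assay on the whole organism (Mus musculus, strain BALB/c) for pharmacokinetics, read by LC-MS, with a stated time of 24 h, at a dose of 1 mg/kg by the intravenous route; on this read-out lower numbers stand for narrower distribution and higher numbers for wider distribution into tissues:
compound 1 `O=S(=O)(Nc1ncccn1)c1ccc2c(c1)OCC[C@@H]2c1ccc(C(F)(F)F)cc1-c1ccc(F)nc1`: 0.8 L/kg
compound 2 `O=S(=O)(Nc1nccs1)c1ccc2c(c1)OCC[C@@H]2c1ccc(C(F)(F)F)cc1-n1ccnn1`: 1 L/kg

Compound 2 stands within the scatter of compound 1, so the two values do not separate. Compound 3 `O=S(=O)(Nc1nccs1)c1ccc2c(c1)OCC[C@@H]2c1ccc(C(F)(F)F)cc1-c1ccc(F)nc1` differs from compound 2 by 6-fluoropyridin-3-yl in place of 1H-1,2,3-triazol-1-yl on an aromatic carbon. Among the compounds with values here, no measured step covers this change, so the data give no direction, and no step beyond the scatter is expected in this assay. The estimated change is a 1.1-fold lower number from compound 2 to compound 3 (0.05 log units; within the scatter). The expected value for compound 3 is 0.9 L/kg, within an estimated range of 0.45 L/kg to 1.8 L/kg.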

Compound 3, volume of distribution at steady state: 2.9 L/kg
For compound 3 the middle estimate is 3.2-fold (0.51 log units) below the measured one; the measured number lies above the stated range.
By their numbers in this assay, from the lowest: compounds 1 and 2 (each within the scatter of the next); then compound 3.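

In this assay, the aromatic carbon ortho to a large group responds to its substituent: 6-fluoropyridin-3-yl in place of 1H-1,2,3-triazol-1-yl gives a 2.9-fold higher number from compound 2 to compound 3 (0.46 log units; beyond the scatter). The sulfonamide nitrogen also responds: 1,3-thiazol-2-yl in place of pyrimidin-2-yl gives a 3.6-fold higher number from compound 1 to compound 3 (0.56 log units; beyond the scatter). Nothing available accounts for either step.

Going by these compounds, both steps end at compound 3, so whether either holds on another background remains open. Also open, on these data alone, is how a primary amine or a carboxylic acid on that aromatic carbon would read.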